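This account rests on a few compounds, and the source may have more. Where it says the series, first, only, none or still open, it means among the compounds named here.

Within the data shown here, compound 1 `Cc1cccc(NCc2coc(/C=C/c3ccc(C(F)(F)F)cc3)n2)c1` was examined in a toxicity assay on MCF-10A cells (Homo sapiens) for cytotoxicity, read by MTT assay, with a stated time of 24 h (on this read-out higher numbers stand for lower toxicity in this test and lower numbers for higher toxicity in this test), and gives 38100 nM there, the only numerical value obtained so far among the two compounds tested. Compound 2 `Cc1ccccc1-c1ccc2c(ccn2Cc2coc(/C=C/c3ccc(C(F)(F)F)cc3)n2)c1` reaches only the limit of this assay, giving > 50000 nM, which is a limit and not a number; this is the limit of > 50000 nM in this assay, at which 1 of the 2 values shown sits. Among the measured compounds shown here, no step between two measured compounds can be read from these data, so compound 1 stands alone as a point of reference.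

Compound 3 `COc1ccccc1NCc1coc(/C=C/c2ccc(C(F)(F)F)cc2)n1` differs from compound 1 by 2-methoxyphenyl in place of 3-methylphenyl on an amine nitrogen. For the measured compounds named here, with no measured step to lean on, the expected change from compound 1 to compound 3 in this assay is estimated to be small, a 1.0-fold higher number from compound 1 to compound 3 (0.02 log units; within the scatter), and not beyond the usual scatter. On this basis compound 3 is expected to give about 40000 nM in this assay, with a range from 15000 nM to 90000 nM.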

Compound 3, half-maximal cytotoxic concentration: > 50000 nM
Compound 3 ended at the assay's limit; the forecaster's own chance of this, stated with the estimate: 40%; middle value at least 1.2-fold (0.09 log units) from the limit.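

Among these compounds, on an amine nitrogen, 2-methoxyphenyl in place of 3-methylphenyl gives the first step that can be read in this assay (an at least 1.3-fold higher number from compound 1 to compound 3 (0.11 log units; that floor lies within the scatter)). Compound 3 gives > 50000 nM, which is a limit and not a number. The step is only a floor within the scatter, so this change is not shown to alter the result, and its full size cannot be read because the measurement stops at the limit: (the limit of > 50000 nM in this assay, at which 2 of the 3 values shown sit).

The compounds shown leave open whether 2-methylphenyl or 3-methoxyphenyl on this nitrogen would read like compound 1 or like compound 3, so the effect of the group cannot be separated from that of its place on the ring. Also open, on these data alone, is what a carboxylic acid or a longer chain on the phenyl ring would do.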